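The compounds below may be only part of what the source reports. "The series", "measured", "known", "first", "only" and "open" are said of these compounds alone.

Working notes on the series, read in an ADME assay for permeability, using PAMPA, with a stated time of 4 h, at pH 7.4; on this read-out higher numbers stand for higher permeability and lower numbers for lower permeability. For the measured compounds named here, compound 2 (`CN(C[C@H]1Cc2ncccc2CN1)[C@H]1CCCc2cccnc21`) gives 1300 nm/s, the higher of the two numbers so far, and compound 1 (`NCCCCN(C[C@H]1Cc2ncccc2CN1)[C@H]1CCCc2cccnc21`) gives 14 nm/s. The next compound to read is compound 3 (`NC/C=C\CN(C[C@H]1Cc2ncccc2CN1)[C@H]1CCCc2cccnc21`), with the change 3-aminoprop-1-en-1-yl in place of hydrogen on a saturated chain carbon bound to an amine nitrogen.

Going by the values given here, one measured step bears on this change. Compound 1 carries 3-aminopropyl at that same place, and the step is large and beyond the scatter: a 93-fold higher number from compound 1 to compound 2 (1.97 log units; beyond the scatter). Among the compounds with values here, the group entering compound 3 has the same name apart from its double bond, and no measured pair isolates that double bond. Compound 1 is therefore the closest guide, and a large step to a lower number is expected, roughly the reverse of the measured step. The expected step is a 52-fold lower number from compound 2 to compound 3 (1.72 log units; beyond the scatter). The estimate for compound 3 is 25 nm/s, with an expected range of 8 nm/s to 80 nm/s.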

Compound 3, apparent permeability: 68 nm/s
For compound 3 the middle estimate is 2.7-fold (0.43 log units) below the measured one, and the stated range covers the measured number.
By their numbers in this assay, from the lowest: compound 1; then compound 3; then compound 2.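

In this assay, a second group on a saturated chain carbon bound to an amine nitrogen now goes with a large step to a lower number (a 19-fold lower number from compound 2 to compound 3 (1.28 log units; beyond the scatter)), so the large drop is no longer tied to 3-aminopropyl alone. For the compounds shown here, compounds 1 and 3 also form the first pair that differs only in the chain, and 3-aminoprop-1-en-1-yl in place of 3-aminopropyl gives a modest step that is still beyond the scatter (a 4.9-fold higher number from compound 1 to compound 3 (0.69 log units; beyond the scatter)), which shows that the number at this place depends on the chain's double bond as well as on the presence of a chain. No measurement at hand gives a reason for either step.

The compounds shown leave open whether the lower numbers go with the amine of the chain or with the chain carbons, a question that a butyl or 4-hydroxybutyl group at this place would address. They also leave open how a longer aminoalkyl chain, or the same chain with the other double-bond geometry, would read against compound 1 and compound 3.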